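Nitro in Place of Chloro on a Shared Core

This account rests on a few compounds, and the source may have more. Where it says the series, first, only, none or still open, it means among the compounds named here.

Three compounds share one core and differ only in the placement or decoration of the same side group: compound 1 `O=C1NC(=O)/C(=C/c2cccc(OCN3C(=O)c4ccccc4C3=O)c2)S1`, compound 2 `O=C1NC(=O)/C(=C/c2ccccc2OCN2C(=O)c3ccccc3C2=O)S1` and compound 3 `O=C1NC(=O)/C(=C/c2cc(Cl)ccc2OCN2C(=O)c3ccccc3C2=O)S1`, which carries a chloro that compound 2 lacks. In an assay on isolated protein for inhibition of Alpha glucosidase (Homo sapiens), read by spectrophotometry, with stated times of 15 min and 30 min (on this read-out higher numbers stand for weaker inhibition and lower numbers for stronger inhibition), compound 1 gives > 100000 nM, a limit of the assay rather than a number. Compound 2 gives > 100000 nM, again only a limit. Compound 3 gives > 100000 nM, likewise a limit. Compound 3 therefore stands with every value shown at the limit described by the limit of > 100000 nM in this assay, at which 3 of the 3 values shown sit, and the step that the two limits leave unreadable from compound 2 to compound 3 cannot be sized. Compound 4 `O=C1NC(=O)/C(=C/c2cc([N+](=O)[O-])ccc2OCN2C(=O)c3ccccc3C2=O)S1` differs from compound 3 by nitro in place of chloro on an aromatic carbon. For the measured compounds named here, no measured step yields a number, so no shift beyond the scatter is expected; the estimated step is a step that the limit leaves unreadable from compound 3 to compound 4. For compound 4 the expected value is 150000 nM, within a range from 60000 nM to 400000 nM.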

Compound 4, half-maximal inhibitory concentration: 50500 nM
Compound 4: middle estimate off by 3.0-fold (0.47 log units), on the high side, outside the stated range (below it).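

Compound 4 is the only compound shown that gives a number rather than a limit, so a change at this position, para to a large group, can bring a reading within range of this assay. Nitro in place of chloro gives an at least 1.9-fold lower number from compound 3 to compound 4 (0.29 log units; that floor lies within the scatter), and nitro in place of hydrogen gives an at least 1.9-fold lower number from compound 2 to compound 4 (0.29 log units; that floor lies within the scatter). Each is only a floor, and the other compounds stay at one limit: the limit of > 100000 nM in this assay, at which 3 of the 4 values shown sit.

Steps between compounds at that limit cannot be read. Going by these compounds, whether an amine or a carboxylic acid at this position would give a lower number than nitro remains open.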